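Swapping methylselanyl for methylsulfanyl on a quinazoline-type core

The source may hold more compounds than are shown below. What is called first, only, known or untested is meant among the compounds shown, and "the series" means these compounds.

The series is read in a functional assay on CCRF-CEM cells (Homo sapiens) for cytotoxicity, read by MTT assay, with a stated time of 72 h; a higher number here means a weaker inhibitor of growth, a lower number a stronger inhibitor of growth. Compound 1 `COc1ccc(CNc2nc(SC)nc3ccccc23)cc1` reaches only the limit of the assay, giving > 100000 nM; this is the limit of > 100000 nM in this assay, at which 1 of the 3 values shown sits. Compound 2 `CSc1nc(NCCCc2ccccc2)c2ccccc2n1` gives a number, 87800 nM, and compound 3 `CSc1ccc(CNc2nc([Se]C)nc3ccccc23)cc1` gives 86900 nM. Of the two compounds with a number, compound 3 sits together with compound 2 within the usual scatter, so no order can be drawn between them, and compound 1 supplies only a limit.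

Compound 4 `CSc1ccc(CNc2nc(SC)nc3ccccc23)cc1` has not yet been measured. It differs from compound 3 in one place: a group of 2 heavy atoms (1 carbon, 1 sulfur; no ring) in place of a group of 2 heavy atoms (1 carbon, 1 selenium; no ring), on an aromatic carbon. Both compound 1 and compound 2 already carry the methylsulfanyl group that enters here, and neither is a strong inhibitor of growth in this assay. Among the measured compounds shown here, no measured step matches this change, so the expectation for the step from compound 3 to compound 4 is none beyond the scatter, with some leaning towards a higher number that could again end at the limit. Compound 4 is therefore estimated at 95000 nM, within 40000 nM to 200000 nM, a step of a 1.1-fold higher number from compound 3 to compound 4 (0.04 log units; within the scatter) that is expected rather than known.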

Compound 4, concentration for total growth inhibition: > 100000 nM
Compound 4: no number, only a limit (the forecaster's own chance of this, stated with the estimate: 40%); middle value at least 1.0-fold (0.02 log units) from the limit.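

Setting methylsulfanyl in place of the selenium-bearing methyl group, on the aromatic carbon between two ring nitrogen atoms, gives an at least 1.1-fold higher number from compound 3 to compound 4 (0.06 log units; that floor lies within the scatter) in this assay. Only a floor is known for this change, so the data show that compound 4 carries no number at this position, but they do not show how large the true step is. Compound 4 ends at a limit of the assay, as compound 1 does, and the step joining those two limits cannot be read: the limit of > 100000 nM in this assay, at which 2 of the 4 values shown sit.

From the compounds shown here alone, whether a methylselanyl group would change the number on the side chain of compound 2 stays open. Also open, going by these compounds, is what an amine or a longer sulfur-bearing chain at the same position would give in this assay.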